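This account rests on a few compounds, and the source may have more. Where it says the series, first, only, none or still open, it means among the compounds named here.

Working notes on the series, read in an ADME assay on L929 cells (Mus musculus, culture collection number NCTC 929) for cytotoxicity, read by MTT assay, with a stated time of 72 h; on this read-out higher numbers stand for weaker inhibition and lower numbers for stronger inhibition. Compound 1 `CCCCCCc1c(O)cc(C)oc1=O` reports only a limit, > 200000 nM. Compound 3 `Cc1cc(O)c(C(=O)Nc2ccccc2)c(=O)o1` also reports only a limit, > 200000 nM. Within the data shown here, compound 2 `CCCCCCCCCCCCCCCCc1c(O)cc(C)oc1=O` gives 38200 nM, and this is the only true number in the set, so it has no measured neighbour to be ranked against.

The next compound to be read is compound 4 `CCCCCCCCCCCCCCc1c(O)cc(C)oc1=O`. Its change from compound 2 is hydrogen in place of ethyl on a saturated chain carbon, ten or more bonds along the chain from an aromatic carbon. The chain stays long and the shared core is untouched.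

Among the measured compounds shown here, no step between measured compounds exists to calibrate this change. A small shift toward higher numbers in this assay is expected, of a size near the scatter and perhaps just beyond it. The direction of that expectation rests on compound 1, whose limit of > 200000 nM goes with a much shorter chain. The estimated change is a 1.7-fold higher number from compound 2 to compound 4 (0.23 log units; within the scatter). For compound 4 the estimated half-maximal inhibitory concentration is 65000 nM, with an expected range of 32000 nM to 160000 nM.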

Compound 4, half-maximal inhibitory concentration: 24100 nM
Beside the measured number, compound 4's estimate is 2.7-fold (0.43 log units) above it; measured number outside the range, below it.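

In this assay, the series now has its first step between two true numbers: a 1.6-fold lower number from compound 2 to compound 4 (0.20 log units; within the scatter), for hydrogen in place of ethyl on a saturated chain carbon, ten or more bonds along the chain from an aromatic carbon. At this place, then, the loss of ethyl from the long chain leaves the read-out within the scatter, and the two compounds carry no order in this assay, while the shared core stays untouched. No step to compound 1 or compound 3 can be read, since each of these reports only a limit and not a number: the limit of > 200000 nM in this assay, at which 2 of the 4 values shown sit.

Left open is whether a chain of intermediate length, such as decyl, gives a true number in this assay or also reports a limit, and whether a longer chain, such as octadecyl, moves the read-out beyond the scatter. Also open, as far as these compounds go, is what an amine or a carboxylic acid would do in place of ethyl at this same place on the chain.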